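The compounds below may be only part of what the source reports. "The series", "measured", "known", "first", "only" and "open" are said of these compounds alone.

Going by the values given here, compound 2 `CCCSCC1(C)Cc2c(C)c(N)c(C)c(C)c2O1` gives 24.6 mg/kg in a functional assay on the whole organism with Mus musculus as the target (a lower number here means that less compound is needed, a higher number that more compound is needed for the effect), the only actual number so far. Compound 1 `Cc1c(C)c2c(c(C)c1N)CC(C)(CSc1ccc(O)cc1)O2` reports only a limit in this assay, > 50 mg/kg.

The next analogue is compound 3 `Cc1c(C)c2c(c(C)c1N)CC(C)(CSCCC(=O)O)O2`, reached by carboxy in place of methyl on a saturated chain carbon, two bonds along the chain from a sulfur; this turns propyl into 2-carboxyethyl. Among the compounds with values here, the one measured step that bears on it is an at least 2.0-fold lower number from compound 1 to compound 2 (0.30 log units; that floor lies within the scatter). That step also concerns the group on the sulfur, but its size is only a floor and rests on (the limit of > 50 mg/kg in this assay, at which 1 of the 2 values shown sits). It offers a weak lead towards a higher number when propyl is replaced, and it fixes no size. A modest rise in this assay is therefore expected, with real uncertainty, and a second limit is possible. The expected change is a 1.8-fold higher number from compound 2 to compound 3 (0.26 log units; within the scatter). For compound 3 the estimate is 45 mg/kg, with an expected range of 18 mg/kg to 110 mg/kg.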

Compound 3, dose for 50% inhibition: 43 mg/kg
Estimate against measurement, compound 3: 1.0-fold (0.02 log units) above, and the stated range covers the measured number.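

Carboxy in place of methyl, on a saturated chain carbon, two bonds along the chain from a sulfur, gives a difference within the scatter in this assay (a 1.7-fold higher number from compound 2 to compound 3 (0.24 log units; within the scatter)). The group on the sulfur can therefore be 2-carboxyethyl as well as propyl with no readable separation between the two, even though carboxy brings a hydrogen-bond donor and acceptor that methyl lacks. The comparison with the 4-hydroxyphenyl group gives only a floor, also within the scatter (an at least 1.1-fold lower number from compound 1 to compound 3 (0.06 log units; that floor lies within the scatter)), and it rests on a limit: the limit of > 50 mg/kg in this assay, at which 1 of the 3 values shown sits.

Still open, as far as these compounds go, is whether the tolerance extends to a primary amine at the chain end, a methyl ester or amide of the carboxylic acid, or a longer chain carrying the carboxy group. Also open, from the compounds shown here alone, is how an oxygen in place of the sulfur would read.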